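Replacing the Chlorophenyl of a Thiourea with an Acetyl Group

The source may report more compounds than this note shows. Statements on the series, on what has been measured and on what is new or still open speak of the compounds shown alone.

Measured compounds:
- compound 1, `FC(F)(F)c1cccc(NC(=S)Nc2ccc(Cl)cc2)c1`: 6800 nM
- compound 2, `CCCC[C@H]1CC[C@H](c2ccc(NC(=S)Nc3cccc(C(F)(F)F)c3)cc2)CC1`: 22000 nM

In an ADME assay on MT4 cells (Homo sapiens) for cytotoxicity (on this read-out higher numbers stand for lower toxicity in this test and lower numbers for higher toxicity in this test), compound 1 gives 6800 nM, the lowest of the two numbers, so it is the more toxic of the pair in this test. Compound 2 sits a 3.2-fold higher number from compound 1 to compound 2 (0.51 log units; beyond the scatter), a change made at an aromatic carbon.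

Compound 3, `CC(=O)NC(=S)Nc1cccc(C(F)(F)F)c1`, has not been measured. It differs from compound 1 in one place: acetyl in place of 4-chlorophenyl on an amide-type nitrogen. For the measured compounds named here, the attachment point is the nitrogen bonded to the thiocarbonyl carbon, not an aromatic carbon, so the one measured step does not speak directly to this change. Without a comparable step, the expectation rests on compound 1 alone, and the step of a 1.3-fold higher number from compound 1 to compound 3 (0.12 log units; within the scatter) is expected to stay close to the scatter. Compound 3 is therefore estimated at 9000 nM, within 3000 nM to 30000 nM.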

Compound 3, half-maximal cytotoxic concentration: > 100000 nM
Compound 3: no number, only a limit; the forecaster's own chance of this, stated with the estimate: 15%; middle value at least 11-fold (1.04 log units) away from the limit.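

Swapping the whole 4-chlorophenyl for acetyl on the amide-type nitrogen moves the read-out far more than changing the substituent on that ring did: this assay shows an at least 14-fold higher number from compound 1 to compound 3 (1.16 log units; beyond the scatter) and points to lower toxicity in this test. So this position matters for the result, and the aromatic ring there is not needed for compound 3 to stay clear of toxicity across the tested range. The reading for compound 3 is a limit of the assay and not a number, so the true size of the step stays unknown: the limit of > 100000 nM in this assay, at which 1 of the 3 values shown sits.

Compound 3 loses a ring and gains a carbonyl in one change, so the shown compounds cannot separate these two parts of the swap. A benzoyl group, which has both the ring and the carbonyl, or a simple ethyl chain, which has neither, would pull them apart.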